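From an Amine Chain End to a Larger Group

The source may hold more compounds than are shown below. What is called first, only, known or untested is meant among the compounds shown, and "the series" means these compounds.

Values measured in a functional assay on HT cells (Homo sapiens) for antiproliferative activity, read by fluorescence, with a stated time of 72 h (on this read-out lower numbers stand for stronger inhibition of growth and higher numbers for weaker inhibition of growth), are as follows
Compound 1 `CC(C)c1n[nH]c2c(NCc3ccc(-c4ccccn4)cc3)nc(SCCO)nc12` gives 48 nM
Compound 2 `CC(C)c1n[nH]c2c(NCc3ccc(-c4ccccn4)cc3)nc(SCC(O)C(F)(F)F)nc12` gives 690 nM
Compound 3 `CC(C)c1n[nH]c2c(NCc3ccc(-c4ccccn4)cc3)nc(SCCN)nc12` gives 22 nM

Compound 3 has the lowest number of the three, and its 22 nM is the starting point for what follows. The change to compound 4 `CC(C)c1n[nH]c2c(NCc3ccc(-c4ccccn4)cc3)nc(SCCNC(=N)N)nc12` is a group of 3 heavy atoms (1 carbon, 2 nitrogen; no ring) in place of a hydrogen atom, on an amine nitrogen and the rest of the structure stays the same. For the measured compounds named here, no measured step makes this exact change, so the evidence is indirect. Two steps are large, a 14-fold higher number from compound 1 to compound 2 (1.16 log units; beyond the scatter) and a 31-fold lower number from compound 2 to compound 3 (1.50 log units; beyond the scatter) and they show that changes at this end of the chain can matter a great deal in this assay here. The third, a 2.2-fold lower number from compound 1 to compound 3 (0.34 log units; beyond the scatter) is modest. The only measured addition of a group, in a 14-fold higher number from compound 1 to compound 2 (1.16 log units; beyond the scatter) raised the number, so a small upward step is expected, although that single case is weak support. The expected step is a 1.8-fold higher number from compound 3 to compound 4 (0.26 log units; within the scatter) and it remains an estimate. Compound 4 is estimated at 40 nM with an expected range from 12 nM to 130 nM in this measurement.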

Compound 4, concentration for 50% growth inhibition: 390 nM
Estimate against measurement, compound 4: 9.8-fold (0.99 log units) below; the whole stated range lies below it.
By their numbers in this assay, from the lowest: compound 3; then compound 1; then compounds 4 and 2 (each within the scatter of the next).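

Adding this group to the amine nitrogen of the chain carries a large cost in this assay, with an 18-fold higher number from compound 3 to compound 4 (1.25 log units; beyond the scatter), so this nitrogen does not accept every addition without a loss. The result also sits well above the hydroxy chain end, with an 8.1-fold higher number from compound 1 to compound 4 (0.91 log units; beyond the scatter), while a 1.8-fold lower number from compound 2 to compound 4 (0.25 log units; within the scatter) leaves compound 2 and compound 4 within the scatter of each other. Among these compounds, then, additions at the chain end on a carbon and on the nitrogen both gave a higher number than the plain hydroxy or amine end.

Nothing shown gives a reason for the rise. From the compounds shown here alone, whether a smaller group on this nitrogen, such as a methyl or an acetyl group, would raise the number as much remains open, as does the effect of a longer chain carrying the amine.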